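This account rests on a few compounds, and the source may have more. Where it says the series, first, only, none or still open, it means among the compounds named here.

Measured compounds in a functional assay on the whole organism for inhibition, with Rattus norvegicus as the target; a higher number here means that more compound is needed for the effect, a lower number that less compound is needed:
- compound 1 `CN(C)C(=O)n1cc(C(=O)c2ccn3c2CSC3c2cccnc2)c2ccc(Cl)cc21`: 1.4 mg/kg
- compound 2 `CN(C)C(=O)n1cc(C(=O)c2ccn3c2CSC3c2cccnc2)c2ccc(-c3ccccc3)cc21`: 0.06 mg/kg
- compound 3 `NC(=O)n1cc(C(=O)c2ccn3c2CSC3c2cccnc2)c2ccc(-c3ccc(F)cc3)cc21`: 0.06 mg/kg

Compound 3 stands level with compound 2 at the digits shown, the two together giving the lowest numbers of the three; compound 1 sits far higher, the gap being a 23-fold lower number from compound 1 to compound 2 (1.37 log units; beyond the scatter) for the phenyl-for-chloro exchange. For the measured compounds named here, compound 2 and compound 3 differ in two places, so their equal values say only that those two changes together leave the dose unchanged.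

Compound 4 `O=C(O)CCn1cc(C(=O)c2ccn3c2CSC3c2cccnc2)c2ccc(-c3ccc(F)cc3)cc21` carries the change (2-carboxyethyl in place of carbamoyl on an aromatic nitrogen). Going by the values given here, no measured single step touches the substituent on this aromatic nitrogen, so nothing here shows how wide such a change swings. The expectation for compound 4 in this assay is therefore centered near compound 3 with a broad range, a 2.0-fold higher number from compound 3 to compound 4 (0.30 log units; within the scatter), giving an estimate of 0.12 mg/kg (range 0.03 mg/kg to 0.6 mg/kg).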

Compound 4, dose for half-maximal effect: 5.1 mg/kg
Compound 4: the middle estimate sits 43-fold (1.63 log units) below what was measured; measured number above the stated range.
By their numbers in this assay, from the lowest: compounds 2 and 3 (each within the scatter of the next); then compound 1; then compound 4.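

The substituent on the aromatic nitrogen is not a free position: in this assay, the exchange of carbamoyl for 2-carboxyethyl gives an 85-fold higher number from compound 3 to compound 4 (1.93 log units; beyond the scatter). The rest of the molecule is unchanged, so the whole step belongs to this one exchange. No measurement at hand accounts for it.

As far as these compounds go, the step changes chain length and end group together, so the share of each stays open. A propyl chain without the carboxylic acid, or a methyl ester of the acid, would separate the two.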